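Hydrazone Series on a Shared Nucleoside Core: Inhibition Readings

This account rests on a few compounds, and the source may have more. Where it says the series, first, only, none or still open, it means among the compounds named here.

Compound 1 `CSCC/C=N/Nc1nc(N)c2ncn([C@@H]3O[C@H](CO)[C@@H](O)[C@H]3O)c2n1` is tested in an assay on CHO-K1 cells for displacement of a labelled ligand from adenosine receptor A1 (Homo sapiens), read by scintillation counting, with a stated time of 60 min, tested at 1 uM (on this read-out higher numbers stand for more inhibition at the one concentration tested (going by the name of the read-out) and lower numbers for less inhibition), and gives 0%. Two hydrazones on the same core are measured with it: compound 2 `Nc1nc(N/N=C/c2ccc(OCc3ccccc3)c(OCc3ccccc3)c2)nc2c1ncn2[C@@H]1O[C@H](CO)[C@@H](O)[C@H]1O` gives 0%, and compound 3 `Nc1nc(N/N=C/c2ccc(C(F)(F)F)cc2C(F)(F)F)nc2c1ncn2[C@@H]1O[C@H](CO)[C@@H](O)[C@H]1O` gives 0%. Compound 1 thus stands level with compound 2 and compound 3 at the digits shown; none of the three separates from the others beyond the scatter, so no order among them can be stated.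

Compound 4 `Nc1nc(N/N=C/c2ccc(Cl)c(C(F)(F)F)c2)nc2c1ncn2[C@@H]1O[C@H](CO)[C@@H](O)[C@H]1O` differs from compound 1 in one place: 4-chloro-3-(trifluoromethyl)phenyl in place of 2-(methylsulfanyl)ethyl on a carbon with a double bond to nitrogen. Among the compounds with values here, no step between measured compounds is available for this change. Since compound 3 gives 0% with a related aryl hydrazone, the step is expected to be none beyond the scatter, a number 2 percentage points higher from compound 1 to compound 4 (within the scatter). Compound 4 is expected to give 2%, estimated between -10% and 15%.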

Compound 4, a percentage reported as inhibition, at one concentration (the size of the read-out at that concentration, not a potency): 11%
Compound 4: middle estimate off by 9 percentage points, on the low side, and the stated range covers the measured number.
By their numbers in this assay, from the lowest: compounds 1, 2 and 3 (each within the scatter of the next); then compound 4.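

Within the data shown here, at the carbon with a double bond to nitrogen, 4-chloro-3-(trifluoromethyl)phenyl in place of 2-(methylsulfanyl)ethyl gives a reading of a number 11 percentage points higher from compound 1 to compound 4 (beyond the scatter) in this assay, the first step beyond the scatter. This place can therefore move the read-out, although compound 4 reaches only 11% at the one concentration tested. No available measurement bears on what lies behind this step.

As far as these compounds go, whether an amine or a carboxylic acid on the phenyl ring would carry the reading further than in compound 4 remains open. So does whether a longer chain in place of 2-(methylsulfanyl)ethyl would move it at all.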